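Propyl removal on the shared core: expectation for compound 3

The source may hold more compounds than are shown below. What is called first, only, known or untested is meant among the compounds shown, and "the series" means these compounds.

Measured so far:
- compound 1 `CCCc1nc(C)c2cnnc(SCC(=O)OCC)n12`; in a functional assay for inhibition, with Homo sapiens as the target (on this read-out lower numbers stand for stronger inhibition and higher numbers for weaker inhibition), compound 1 gives > 48000 nM, which is a limit of the assay.
- compound 2 `CCCc1nc(C)c2cnnc(SC)n12`; in this assay compound 2 gives > 48000 nM, which is a limit of the assay.

Compound 1 stands only at a limit in this assay. For the measured compounds named here, the one further value shown is also a limit, so both values sit at the limit of > 48000 nM in this assay, at which 2 of the 2 values shown sit. The step that the two limits leave unreadable from compound 1 to compound 2, hydrogen in place of ethoxycarbonyl on a saturated chain carbon bound to a sulfur, therefore cannot be read in size.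

Compound 3 `CCOC(=O)CSc1nncc2c(C)ncn12` differs from compound 1 by hydrogen in place of propyl on an aromatic carbon, between two ring nitrogen atoms, two ring bonds from the ring atom that bears a methyl group. No measured step touches this position, and the only step shown is unreadable. For compound 3 in this assay no move beyond the scatter is expected; a limit again is the likely outcome. The step expected is a step that the limit leaves unreadable from compound 1 to compound 3. Compound 3 is estimated at 100000 nM, with a range from 30000 nM to 500000 nM.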

Compound 3, half-maximal inhibitory concentration: > 48000 nM
Compound 3 was reported as a limit (the forecaster's own chance of this, stated with the estimate: 85%); the middle value does not contradict the limit.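

No size can be read for the step from compound 1 to compound 3, nor for any other step among compounds 1, 2 and 3, as all remain at a limit: the limit of > 48000 nM in this assay, at which 3 of the 3 values shown sit.

The compounds shown leave open what size, if any, hydrogen in place of propyl has on inhibition, and which change to the shared core would give a value inside the range of this assay.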